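The source may hold more compounds than are shown below. What is called first, only, known or untested is meant among the compounds shown, and "the series" means these compounds.

Compound 1 `CCC/N=C1\S/C(=C\c2ccc(O)c(Cl)c2)C(=O)N1c1ccccc1C` carries a methyl on the aromatic ring attached to the core nitrogen, and in a physicochemical assay for lipophilicity, read by HPLC, at pH 7.4 (on this read-out lower numbers stand for lower lipophilicity and higher numbers for higher lipophilicity), compound 1 gives 3.8. Compound 2 `CCC/N=C1\S/C(=C\c2ccc(O)c(Cl)c2)C(=O)N1c1ccccc1OC` has methoxy in place of that methyl, and in this assay compound 2 gives 3.3, which is the lowest of the three numbers measured; the change is a number 0.50 log units lower from compound 1 to compound 2 (beyond the scatter). Compound 3 `CCC/N=C1\S/C(=C\c2ccc(O)c(C(F)(F)F)c2)C(=O)N1c1ccccc1C` has trifluoromethyl in place of chloro on the other aromatic ring, and in this assay compound 3 gives 3.8, a change of no change at the digits printed from compound 1 to compound 3 (within the scatter).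

Compound 4 `CCC/N=C1\S/C(=C\c2ccc(O)c(Cl)c2)C(=O)N1c1ccccc1O` is not yet measured. Its difference from compound 2 is hydrogen in place of methyl on an oxygen on an aromatic ring. Among the compounds with values here, no measured step replaces methoxy with hydroxy; the only step touching this ring is the one from compound 1 to compound 2, which was modest. In this assay compound 4 is expected to sit somewhat lower than compound 2, an estimated step of a number 0.40 log units lower from compound 2 to compound 4 (beyond the scatter), giving an estimated value of 2.9 with a range from 2.4 to 3.4.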

Compound 4, distribution coefficient: 2.7
For compound 4 the middle estimate is 0.20 log units above the measured one, and the stated range covers the measured number.
By their numbers in this assay, from the lowest: compound 4; then compound 2; then compounds 1 and 3 (each within the scatter of the next).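

Hydrogen in place of methyl on an oxygen on an aromatic ring gives a clear step in this assay, namely a number 0.60 log units lower from compound 2 to compound 4 (beyond the scatter). Until now, this place on the molecule had shown only the change from methyl to methoxy; hydroxy in place of methyl now gives a large step, a number 1.10 log units lower from compound 1 to compound 4 (beyond the scatter), so the three groups read in the order methyl, methoxy, hydroxy, from the highest number to the lowest. No measurement shown here explains why these numbers move as they do.

The compounds shown leave open where an amine or a longer chain such as ethoxy would fall in this order at the same place. They also leave open whether hydroxy would give a similar step with trifluoromethyl in place of chloro on the other aromatic ring.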